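The source may hold more compounds than are shown below. What is called first, only, known or untested is meant among the compounds shown, and "the series" means these compounds.

Measured so far:
compound 1, `COc1cc(-c2nc(SCc3cn(CC(=O)NC(=O)Nc4ccccn4)nn3)nc(Nc3cccc(Cl)c3)c2C#N)cc(OC)c1OC`, 15400 nM
compound 2, `COc1ccccc1Nc1nc(SCc2cn(CC(=O)NC(=O)Nc3ccccn3)nn2)nc(-c2ccc(C)cc2)c1C#N`, 7960 nM

In a functional assay on MGC-803 cells (Homo sapiens) for inhibition, read by MTT assay, with a stated time of 72 h (on this read-out lower numbers stand for stronger inhibition and higher numbers for weaker inhibition), compound 1 gives 15400 nM. In this assay compound 2 gives 7960 nM, which is the lower of the two numbers, but the gap to compound 1 lies within the usual scatter of repeated measurements, so the two cannot be told apart with confidence.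

Compound 3, `Cc1ccc(-c2nc(SCc3cn(CC(=O)NC(=O)Nc4ccccn4)nn3)nc(Nc3cccc(Cl)c3)c2C#N)cc1`, has not yet been measured. It is built from compound 2 by a single exchange: 3-chlorophenyl in place of 2-methoxyphenyl on a nitrogen on an aromatic ring. Going by the values given here, since no pair of measured compounds differs only at this position, the effect of the exchange cannot be read off from the available numbers. Compound 1 does carry the (3-chlorophenyl)amino group, yet with a different other aryl group, so it serves only as a rough pointer.

With nothing beyond that to go on, the expected step of a 1.3-fold higher number from compound 2 to compound 3 (0.10 log units; within the scatter) is small and probably not beyond the scatter. Compound 3 is therefore estimated at 10000 nM in this assay, with a plausible range from 4000 nM to 25000 nM.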

Compound 3, half-maximal inhibitory concentration: 7890 nM
Compound 3: middle estimate off by 1.3-fold (0.10 log units), on the high side; low and high end bracket the measured number.
By their numbers in this assay, from the lowest: compounds 3, 2 and 1 (each within the scatter of the next).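

In this assay, going by these compounds alone, 3-chlorophenyl in place of 2-methoxyphenyl on a nitrogen on an aromatic ring gives a 1.0-fold lower number from compound 2 to compound 3 (0.00 log units; within the scatter) and so provides the first direct reading at this position: swapping these two groups has no effect that can be told from the scatter. The other aryl group can now be read directly too, as 4-methylphenyl in place of 3,4,5-trimethoxyphenyl on an aromatic carbon gives a 2.0-fold lower number from compound 1 to compound 3 (0.29 log units; within the scatter) and that exchange also cannot be told from the scatter. No measurement here offers an explanation for either result.

Going by these compounds, all three compounds carry a substituted phenyl on that nitrogen, so it remains open whether a longer chain ending in an amine, or a carboxylic acid, would shift the number beyond the scatter. On these data alone, whether either exchange would give the same result on a different core also remains open.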